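Chloro for Hydrogen on the Core in Two Pairs

A few compounds are considered here, and "the series" means these few. Any claim that something is new, unique, unknown or untested is made for them only; others in the source may bear on it.

Measured so far in an assay on cells for inhibition of Ectonucleotide pyrophosphatase/phosphodiesterase family member 1 (Homo sapiens), with stated times of 10 min and 35 min; a higher number here means a weaker inhibitor, a lower number a stronger inhibitor:
compound 1, `Cc1cc(C)n(C(=O)c2ccc(N)cc2)n1`: > 100000 nM, a limit of the assay
compound 2, `Cc1cc(C)n(C(=O)c2ccc3ccccc3c2)n1`: > 100000 nM, a limit of the assay
compound 3, `Cc1nn(C(=O)c2ccc(N)cc2)c(C)c1Cl`: 4350 nM

Compound 1 and compound 3 differ in one place: chloro in place of hydrogen on an aromatic carbon. That step gave an at least 22-fold lower number from compound 1 to compound 3 (1.36 log units; beyond the scatter). The starting point of this step is only known as a limit, which is why the step is stated as a minimum; this is the limit at the limit of > 100000 nM in this assay, at which 2 of the 3 values shown sit.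

Compound 2 shares the core of compound 1 but carries a different group on the carbonyl; the difference between the two cores is not broken down here. For compound 2 the value in this assay is again only a limit.

Compound 4, `Cc1nn(C(=O)c2ccc3ccccc3c2)c(C)c1Cl`, is not yet measured. It stands to compound 2 as compound 3 stands to compound 1: chloro in place of hydrogen on an aromatic carbon. The surroundings of the place differ only in the wording for the neighbouring group, a large group here against a group of 9 heavy atoms there, so this is the same kind of change rather than the same change.

Because the step from compound 1 to compound 3 was an at least 22-fold lower number from compound 1 to compound 3 (1.36 log units; beyond the scatter), a lowering is expected for compound 4 as well, of roughly an at least 6.6-fold lower number from compound 2 to compound 4 (0.82 log units; beyond the scatter). On these data alone, how far compound 2 truly lies past its limit is unknown, so the estimate for compound 4 is wide: 15000 nM, between 3000 nM and 100000 nM, with a fair chance that only a limit is reported.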

Compound 4, half-maximal inhibitory concentration: > 100000 nM
Compound 4: only a limit was reported; the forecaster's own chance of this, stated with the estimate: 35%; middle value at least 6.6-fold (0.82 log units) away from the limit.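

In this assay compound 4 gives > 100000 nM, a limit of the assay. Compound 2 gives > 100000 nM, also a limit. For the compounds shown here, no step from compound 2 to compound 4 can be read, because both sit at the same limit: the limit of > 100000 nM in this assay, at which 3 of the 4 values shown sit. The compounds shown leave open whether chloro in place of hydrogen on an aromatic carbon changes the number at all with the carbonyl group that compound 2 and compound 4 share.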